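A few compounds are considered here, and "the series" means these few. Any claim that something is new, unique, unknown or untested is made for them only; others in the source may bear on it.

Measured so far:
- compound 1 `Cn1c(-c2ccc(NC(=O)CSc3nc4ccccc4s3)cc2)nc(-c2ccccc2)c1-c1ccccc1`, in a functional assay on MCF7 cells (Homo sapiens) for cytotoxicity, read by MTT assay, with a stated time of 24 h, tested at 16 ug/mL (a higher number here means a stronger effect of the compound at the concentration tested, a lower number a weaker effect), compound 1 gives 50.3%
- compound 2 `Cn1nnnc1SCC(=O)Nc1ccc(-c2nc(-c3ccccc3)c(-c3ccccc3)n2C)cc1`, in this assay compound 2 gives 63.7%
- compound 3 `CCN1CCN(CC(=O)Nc2ccc(-c3nc(-c4ccccc4)c(-c4ccccc4)n3C)cc2)CC1`, in this assay compound 3 gives 32.8%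

Compound 3 stands lowest of the three numbers in this assay: the step of a number 17.5 percentage points lower from compound 1 to compound 3 (beyond the scatter) is modest, the step of a number 30.9 percentage points lower from compound 2 to compound 3 (beyond the scatter) is large, and both lie beyond the scatter. The remaining step, a number 13.4 percentage points higher from compound 1 to compound 2 (beyond the scatter), is modest and also beyond the scatter.

Compound 4 `CN(C)/C=C/N1CCN(CC(=O)Nc2ccc(-c3nc(-c4ccccc4)c(-c4ccccc4)n3C)cc2)CC1` differs from compound 3 in one place: 2-(dimethylamino)ethenyl in place of ethyl on an amine nitrogen in a ring. None of the three measured steps touches this position; each of them exchanges the whole group on the saturated chain carbon bound to the carbonyl carbon, whereas the step from compound 3 to compound 4 keeps the piperazine ring and changes only what sits on its second ring nitrogen. Among the compounds with values here, there is thus no measured step from which a direction can be read. The expected step of a number 3.2 percentage points higher from compound 3 to compound 4 (within the scatter) is therefore taken as one that does not go beyond the scatter. Compound 4 is estimated at 36% in this assay, within 20% to 54%.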

Compound 4, a percentage reported as activity, at one concentration (the size of the read-out at that concentration, not a potency): 19.4%
Beside the measured number, compound 4's estimate is 16.6 percentage points above it; measured number outside the range, below it.
By their numbers in this assay, from the lowest: compound 4; then compound 3; then compound 1; then compound 2.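

Within the data shown here, with the piperazine ring kept, 2-(dimethylamino)ethenyl in place of ethyl on an amine nitrogen in a ring gives a number 13.4 percentage points lower from compound 3 to compound 4 (beyond the scatter) in this assay, so this position alters the read-out on its own, which the earlier steps could not show because each exchanged the whole group on the saturated chain carbon. The steps to the sulfanyl compounds grow as well, with a number 44.3 percentage points lower from compound 2 to compound 4 (beyond the scatter) and a number 30.9 percentage points lower from compound 1 to compound 4 (beyond the scatter), leaving compound 4 lowest of the four. No supporting data bear on why this exchange lowers the number.

Only two groups on this ring nitrogen are shown, so it stays open whether the double bond or the terminal dimethylamino nitrogen goes with the lower number. A saturated 2-(dimethylamino)ethyl chain on the same nitrogen would separate the two.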